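Notes on an oxazole ketone series: nitro for fluoro

The source may hold more compounds than are shown below. What is called first, only, known or untested is meant among the compounds shown, and "the series" means these compounds.

Measured so far:
compound 1 `O=C(CCCCC#Cc1cccc(Cl)c1Cl)c1ncc(-c2ccccn2)o1` – 5 nM
compound 2 `O=C(CCCCC#Cc1cccc(F)c1)c1ncc(-c2ccccn2)o1` – 3.2 nM

In an assay for inhibition of Fatty-acid amide hydrolase 1 (Rattus norvegicus) (on this read-out lower numbers stand for stronger inhibition and higher numbers for weaker inhibition), compound 1 gives 5 nM and compound 2 gives 3.2 nM. Going by the values given here, the only step so far, a 1.6-fold lower number from compound 1 to compound 2 (0.19 log units; within the scatter), replaces 2,3-dichlorophenyl with 3-fluorophenyl on the triple-bonded carbon and stays within the scatter, so compound 2 has the lowest of the two numbers without being separated from compound 1 by more than the scatter.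

Compound 3 `O=C(CCCCC#Cc1cccc([N+](=O)[O-])c1)c1ncc(-c2ccccn2)o1` differs from compound 2 by nitro in place of fluoro on an aromatic carbon, that is 3-fluorophenyl to 3-nitrophenyl, with the new group on an aromatic carbon of the carbon-only six-membered ring, meta to a large group. Among the compounds with values here, the one measured step that touches this ring, a 1.6-fold lower number from compound 1 to compound 2 (0.19 log units; within the scatter), shows that the substitution pattern there moves the number little. Within the data shown here, no measured step trades a halogen for nitro, so the expectation rests on that single step alone. Compound 3 is therefore expected to come out near compound 2 in this assay, with a 1.6-fold higher number from compound 2 to compound 3 (0.19 log units; within the scatter) as the expected shift, and the estimate for compound 3 is 5 nM within 1.5 nM to 16 nM.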

Compound 3, inhibition constant: 4.8 nM
Compound 3: middle estimate off by 1.0-fold (0.02 log units), on the high side; the range from low to high includes it.
By their numbers in this assay, from the lowest: compounds 2, 3 and 1 (each within the scatter of the next).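

In this assay, nitro, with 3 heavy atoms and 2 hydrogen-bond acceptors, stands in place of fluoro, with 1 heavy atom and none, and the result is a 1.5-fold higher number from compound 2 to compound 3 (0.18 log units; within the scatter) and no more, so this aromatic carbon accepts the larger group without a step beyond the scatter. The change of the whole aryl group gives a 1.0-fold lower number from compound 1 to compound 3 (0.02 log units; within the scatter) as well, which means that the three aryl groups shown cannot be told apart on this read-out. No evidence is available that bears on why the numbers stay together.

From the compounds shown here alone, whether the same holds for an amine or a carboxylic acid on this aromatic carbon remains open. Also open, going by these compounds, is whether a longer chain in place of the present one keeps the number in this range.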